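Dimethylaminoethyl in Place of Carboxymethyl on the Core

The source may report more compounds than this note shows. Statements on the series, on what has been measured and on what is new or still open speak of the compounds shown alone.

The series rests on a shared core. Compound 1 `Nc1nc2ccc(I)cc2s1` carries iodo on an aromatic carbon, compound 2 `CC(C)(C)Oc1ccc2nc(N)sc2c1` has tert-butoxy in place of iodo on an aromatic carbon, and compound 3 `N=c1sc2cc(OC(F)(F)F)ccc2n1CC(=O)O` bears a carboxymethyl chain on an aromatic nitrogen. In a functional assay on the whole organism with Rattus norvegicus as the target (a lower number here means that less compound is needed, a higher number that more compound is needed for the effect), compound 1 gives > 10 mg/kg, which is a limit of the assay and not a number. Compound 2 gives > 10 mg/kg in this assay, again only a limit. Compound 3 likewise reaches only a limit, > 10 mg/kg, in this assay. Hence the step that the two limits leave unreadable from compound 1 to compound 2 cannot be sized, and the limit of > 10 mg/kg in this assay, at which 3 of the 3 values shown sit, is the whole of the measured evidence.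

Compound 4 `CN(C)CCn1c(=N)sc2cc(OC(F)(F)F)ccc21` differs from compound 3 by (dimethylamino)methyl in place of carboxy on a saturated chain carbon bound to an aromatic nitrogen. Among the compounds with values here, no measured step touches the saturated chain carbon bound to an aromatic nitrogen; the single known step, a step that the two limits leave unreadable from compound 1 to compound 2, concerns an aromatic carbon and is unreadable. There is therefore no basis for expecting a change beyond the scatter in this assay, and a further limit is the likelier outcome. Compound 4 is nonetheless estimated at 20 mg/kg in this assay, with a range from 5 mg/kg to 80 mg/kg. That corresponds to an expected step that the limit leaves unreadable from compound 3 to compound 4.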

Compound 4, dose for half-maximal effect: 2.3 mg/kg
Compound 4: the middle estimate sits 8.7-fold (0.94 log units) above what was measured, outside the stated range (below it).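

In this assay, replacing the carboxymethyl chain with 2-(dimethylamino)ethyl gives an at least 4.3-fold lower number from compound 3 to compound 4 (0.63 log units; beyond the scatter), and less compound is needed for the effect. Within the data shown here, this is the first step that can be read, as the only earlier step, on an aromatic carbon, is left unreadable by its two limits. It shows that a change on the saturated chain carbon bound to an aromatic nitrogen can move the result beyond the usual scatter, and compound 4 alone among the compounds shown gives a number rather than a limit: the limit of > 10 mg/kg in this assay, at which 3 of the 4 values shown sit.

The compounds shown do not separate the loss of the carboxy from the arrival of the (dimethylamino)methyl, and the size of the step remains bounded on one side only, as the value of compound 3 is a limit. They also leave open whether a primary amine, a diethylamino group or a longer chain carrying the same amine would hold this result, and whether it would survive with iodo or tert-butoxy on the core in place of the group that compound 4 carries.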